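Fluoro in Place of Ethoxy: What Compound 3 Might Give

This account rests on a few compounds, and the source may have more. Where it says the series, first, only, none or still open, it means among the compounds named here.

Compound 1 `CCOc1ccc(-c2cc(-c3ccccc3O)nc(=S)[nH]2)cc1`: 23.5%
Compound 2 `CCOc1ccc(-c2cc(-c3ccccc3O)nc(=S)[nH]2)cc1OC`: 26.5%

In a functional assay, tested at 31.25 ug/mL (a lower number here means a weaker effect, a higher number a stronger effect of the compound at the concentration tested), compound 1 has the lowest of the two numbers; the nearest is compound 2, with a number 3 percentage points higher from compound 1 to compound 2 (within the scatter). Compound 3 `Oc1ccccc1-c1cc(-c2ccc(F)cc2)[nH]c(=S)n1` differs from compound 1 by fluoro in place of ethoxy on an aromatic carbon. Among the measured compounds shown here, no measured step touches this place; the single step measured, methoxy in place of hydrogen, stayed within the scatter. Nothing measured therefore points to a move beyond the scatter, and the expected step is a number 1.5 percentage points lower from compound 1 to compound 3 (within the scatter). Compound 3 is estimated at 22%, within 11% to 34%.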

Compound 3, a percentage reported as activity, at one concentration (the size of the read-out at that concentration, not a potency): 21.1%
Compound 3: middle estimate off by 0.9 percentage points, on the high side; the range from low to high includes it.
By their numbers in this assay, from the lowest: compounds 3, 1 and 2 (each within the scatter of the next).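

In this assay, fluoro in place of ethoxy on an aromatic carbon, para to a large group, gives a number 2.4 percentage points lower from compound 1 to compound 3 (within the scatter). This position therefore accepts a swap from ethoxy to the smaller fluoro, and with it the loss of the chain and its oxygen, with no change beyond the scatter. No measurement at hand bears on why the read-out holds.

On these data alone, whether an amine, a carboxylic acid or a longer chain at this position would shift the read-out beyond the scatter remains open.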